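Oxadiazole in place of the oxime ether on the shared core

A few compounds are considered here, and "the series" means these few. Any claim that something is new, unique, unknown or untested is made for them only; others in the source may bear on it.

Compound 1 `CCO/N=C/c1cc(C)c(OCCC(C)CCN2CCN(c3ccnc(N)c3)C2=O)c(C)c1` gives the lowest of the two numbers reported as numbers in an ADME assay on RD cells (Homo sapiens) for cytotoxicity, read by MTT assay, with a stated time of 24 h (on this read-out lower numbers stand for higher toxicity in this test and higher numbers for lower toxicity in this test), at 12900 nM. Compound 2 `CC(CCOc1ccc(-c2noc(C(C)(C)C)n2)cc1)CCN1CCN(c2ccnc(N)c2)C1=O` gives a higher number, 55000 nM, in this assay. Compound 3 `CCONC(=O)c1ccc(OCCC(C)CCN2CCN(c3ccnc(N)c3)C2=O)cc1` reaches only a limit in this assay, > 100000 nM, and that is the limit of > 100000 nM in this assay, at which 1 of the 3 values shown sits. Among the compounds with values here, the one step between measured compounds, an at least 1.8-fold higher number from compound 2 to compound 3 (0.25 log units; that floor lies within the scatter), removes a 1,2,4-oxadiazolyl ring from the aromatic carbon and sits at a floor that the scatter covers.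

Compound 4 `Cc1nc(-c2cc(C)c(OCCC(C)CCN3CCN(c4ccnc(N)c4)C3=O)c(C)c2)no1` differs from compound 1 by a group of 6 heavy atoms (3 carbon, 2 nitrogen, 1 oxygen; one five-membered aromatic ring with 3 hetero atoms) in place of a group of 5 heavy atoms (3 carbon, 1 nitrogen, 1 oxygen; no ring), on an aromatic carbon. Within the data shown here, the only measured step that bears on this change is the one from compound 2 to compound 3, which runs in the opposite sense, with the oxadiazolyl ring leaving rather than entering, and its size is not resolved beyond the scatter. Two limits of different compounds do not give a direction for the entering ring on its own. Compound 4 is therefore expected to show a step of a 1.1-fold lower number from compound 1 to compound 4 (0.03 log units; within the scatter), which is taken as none beyond the scatter. For compound 4 the estimate in this assay is 12000 nM, with the range 4000 nM to 40000 nM.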

Compound 4, half-maximal cytotoxic concentration: 28800 nM
Compound 4: the middle estimate sits 2.4-fold (0.38 log units) below what was measured; the measured number falls inside the stated range.
By their numbers in this assay, from the lowest: compound 1; then compounds 4 and 2 (each within the scatter of the next). At a limit, above all of these: compound 3.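

With the two methyl groups in place, the aromatic carbon para to a large group tolerates this exchange with a measurable shift in this assay: the 5-methyl-1,2,4-oxadiazol-3-yl group entering for the oxime ether gives a 2.2-fold higher number from compound 1 to compound 4 (0.35 log units; beyond the scatter), which points to lower toxicity in this test. Within the data shown here, the earlier compounds offered only one step involving an oxadiazolyl ring, on a ring without the two methyl groups, with the ring leaving and a floor that stayed inside the scatter, so this is the first such change resolved beyond the scatter, and it is modest in size. Nothing among the measurements shown accounts for this step.

From the compounds shown here alone, it remains open whether the step belongs to the oxadiazole ring itself or to its methyl substituent, and whether it would hold with a 5-(tert-butyl)-1,2,4-oxadiazol-3-yl group at this carbon or with the two methyl groups gone from the ring. Going by these compounds, how a carboxylic acid or a primary amine at the same aromatic carbon would read in this assay also stays open.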